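Replacing a Fluorobenzyl Amide with a Methylphenyl Amide

The source may hold more compounds than are shown below. What is called first, only, known or untested is meant among the compounds shown, and "the series" means these compounds.

Compound 2 `COc1ccc2c(=O)c(/C=C/C(=O)NCc3ccccc3F)coc2c1` is one of three close analogues sharing a core that differs only in the group on the amide-type nitrogen. In a functional assay on Huh-7 cells (Homo sapiens) for inhibition, read by MTT assay, with a stated time of 48 h (on this read-out lower numbers stand for stronger inhibition and higher numbers for weaker inhibition), compound 2 gives 8450 nM, the higher of the two numbers available, though its nearest neighbour, compound 1 `O=C(/C=C/c1coc2cc(O)ccc2c1=O)NCc1ccccc1`, gives 4690 nM and the gap between them lies within the scatter. Compound 3 `COc1ccc(NC(=O)/C=C/c2coc3cc(O)ccc3c2=O)cc1` gives only a limit in this assay, > 100000 nM. Among the measured compounds shown here, the single measured step, an at least 21-fold higher number from compound 1 to compound 3 (1.32 log units; beyond the scatter), is the one that bears on the change studied here, since compound 4 `COc1ccc2c(=O)c(/C=C/C(=O)Nc3ccc(C)cc3)coc2c1` likewise carries 4-methylphenyl in place of 2-fluorobenzyl on an amide-type nitrogen. In both pairs a benzyl or 2-fluorobenzyl gives way to a 4-methoxyphenyl or 4-methylphenyl on the same amide-type nitrogen, and in the measured pair this produced an at least large loss of inhibition, reaching (the limit of > 100000 nM in this assay, at which 1 of the 3 values shown sits). Compound 4 is therefore expected to give 100000 nM in this assay, within the range 30000 nM to 300000 nM, which corresponds to an expected step of a 12-fold higher number from compound 2 to compound 4 (1.07 log units; beyond the scatter) and may well turn out to be a limit as well.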

Compound 4, half-maximal inhibitory concentration: > 100000 nM
Compound 4 gave a limit, no number; the forecaster's own chance of this, stated with the estimate: 60%; the middle value lies on the limit itself.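

With the 4-methylphenyl in place of 2-fluorobenzyl on the amide-type nitrogen, this assay shows an at least 11-fold higher number from compound 2 to compound 4 (1.07 log units; beyond the scatter). The earlier step, an at least 21-fold higher number from compound 1 to compound 3 (1.32 log units; beyond the scatter), came from a single pair on the core of compound 1, so the present step shows that the same kind of loss also appears on the core of compound 2, with a different group on each side of the change. Compound 3 and compound 4 now end at the same place, so both steps are lower bounds that cannot be ranked against each other, and neither shows how far inhibition actually falls: the limit of > 100000 nM in this assay, at which 2 of the 4 values shown sit.

The compounds shown do not separate the effect of losing the benzyl carbon link from that of the 4-methyl and 4-methoxy groups on the ring, a question that a plain phenyl or a 2-phenylethyl group on this nitrogen would address. They also leave open whether a benzyl carrying a 4-methyl group, or a benzyl with an amine on its ring, would keep inhibition on this nitrogen.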